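This account rests on a few compounds, and the source may have more. Where it says the series, first, only, none or still open, it means among the compounds named here.

For the measured compounds named here, in an in vitro ADME assay on microsomes from liver (Homo sapiens) for metabolic stability (a lower number here means slower removal, a higher number faster removal of the compound), compound 1 `CCC(CC)[C@@H]1C(=O)N[C@H](C2Cc3ccccc3C2)C(=O)N1[C@@H](C(=O)N1CCOCC1)c1ccc(C)nc1` stands at 12 mL.min-1.g-1 as the higher of the two numbers so far. Compound 2 `CC[C@H](C)[C@@H]1C(=O)N[C@H](C2Cc3ccccc3C2)C(=O)N1[C@@H](C(=O)NC)c1cnc(C)cc1C` stands at 7 mL.min-1.g-1 and that gap lies within the usual scatter of repeated measurements, so the two cannot really be told apart. Compound 3 `CCC(CC)[C@@H]1C(=O)N[C@H](C2Cc3ccccc3C2)C(=O)N1[C@@H](C(=O)N1CCOCC1)c1ccc(C)nc1C` has not been measured yet. It is compound 1 with a single change, a methyl in place of hydrogen on an aromatic carbon and this methyl sits next to the ring nitrogen, turning 6-methylpyridin-3-yl into 2,6-dimethylpyridin-3-yl. Going by the values given here, no measured pair of compounds differs in just one place, so the data give no direct guide to such a step. The estimated step of a 1.1-fold lower number from compound 1 to compound 3 (0.04 log units; within the scatter) is therefore expected to stay within the scatter in this assay and to have no clear direction. The estimate for compound 3 is an expected 11 mL.min-1.g-1 with a range from 6 mL.min-1.g-1 to 20 mL.min-1.g-1 around it.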

Compound 3, intrinsic clearance in microsomes: 11 mL.min-1.g-1
Estimate against measurement, compound 3: no gap at the digits printed; the range from low to high includes it.
By their numbers in this assay, from the lowest: compounds 2, 3 and 1 (each within the scatter of the next).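

For the compounds shown here, the step from 6-methylpyridin-3-yl to 2,6-dimethylpyridin-3-yl gives the first comparison in this set between compounds that differ in only one place: in this assay, it is a 1.1-fold lower number from compound 1 to compound 3 (0.04 log units; within the scatter). On this evidence, a methyl can stand in place of hydrogen on this aromatic carbon, next to the ring nitrogen and ortho to a large group, without separating the two compounds in this read-out. Nothing available explains this result.

A single methyl cannot show what an ethyl group, a methoxy group, a chlorine atom or an amine on the same carbon would do. Going by these compounds, it also remains open whether a methyl on another carbon of this ring would read the same way, or whether this step would hold in other compounds.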